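A few compounds are considered here, and "the series" means these few. Any claim that something is new, unique, unknown or untested is made for them only; others in the source may bear on it.

Compound 1 `N[C@H]1CC[C@H](Nc2nc(Nc3ccc(Oc4nccs4)cc3)c3ncn(C4CCCC4)c3n2)CC1` and compound 2 `NCCCCNc1nc(Nc2ccc(Oc3nccs3)cc2)c2ncn(C3CCCC3)c2n1` share one core and differ in a single place: 4-aminobutyl in place of 4-aminocyclohexyl on a nitrogen on an aromatic ring. In an ADME assay on CCRF-CEM cells (Homo sapiens) for inhibition, read by fluorescence and resazurin assay, with a stated time of 72 h (on this read-out higher numbers stand for weaker inhibition of growth and lower numbers for stronger inhibition of growth), compound 1 gives 650 nM, whereas compound 2 gives 8640 nM, so that the change brings a 13-fold higher number from compound 1 to compound 2 (1.12 log units; beyond the scatter). Compound 3 `N[C@H]1CC[C@H](Nc2nc(Nc3ccc(N4CCN(Cc5ccccc5)CC4)cc3)c3ncn(C4CCC(O)C4)c3n2)CC1` stands on another core; how that core differs from the core of compound 1 is not broken down here. In this assay compound 3 gives 540 nM, a number that lies within the scatter of compound 1. Compound 4 `NCCCCNc1nc(Nc2ccc(N3CCN(Cc4ccccc4)CC3)cc2)c2ncn(C3CCC(O)C3)c2n1` has not yet been measured. Going by the values given here, it differs from compound 3 by 4-aminobutyl in place of 4-aminocyclohexyl on a nitrogen on an aromatic ring, the same change as the one that turns compound 1 into compound 2, the place being the same in both pairs. Among the compounds with values here, because the only measured instance of this change reads a 13-fold higher number from compound 1 to compound 2 (1.12 log units; beyond the scatter), the step from compound 3 to compound 4 is expected to be of similar size, a 13-fold higher number from compound 3 to compound 4 (1.11 log units; beyond the scatter), though this rests on a single pair. Compound 4 is therefore estimated at 7000 nM in this assay, with a likely range from 2500 nM to 20000 nM.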

Compound 4, concentration for 50% growth inhibition: 3670 nM
Beside the measured number, compound 4's estimate is 1.9-fold (0.28 log units) above it, and the stated range covers the measured number.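

Putting 4-aminobutyl in place of 4-aminocyclohexyl on the core of compound 3 again raises the number in this assay, giving a 6.8-fold higher number from compound 3 to compound 4 (0.83 log units; beyond the scatter), so the direction seen on the core of compound 1 carries over and the two steps agree in size as far as the scatter can tell: the same change on two cores in this assay, a 13-fold higher number (1.12 log units; beyond the scatter) from compound 1 to compound 2 and a 6.8-fold higher number (0.83 log units; beyond the scatter) from compound 3 to compound 4, 2.0-fold (0.29 log units) apart, within the scatter of two such steps. On both cores shown, the compound with the open chain inhibits growth more weakly than its partner with the ring, and neither pair goes against this. Going by these compounds alone, the finding rests on only two pairs in a single cell assay, however, so it does not show that the change would behave alike on a further core, nor does it explain why the two compounds of each pair differ.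

The compounds shown leave open how a longer chain such as 5-aminopentyl, or a shorter one such as 3-aminopropyl, would read in this series. They also leave open whether 4-hydroxycyclohexyl, with a hydroxyl in place of the amine, would read like 4-aminocyclohexyl.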